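From compound 3 to compound 4 at the carbonyl carbon

The source may report more compounds than this note shows. Statements on the series, on what has been measured and on what is new or still open speak of the compounds shown alone.

Compound 1 `COc1ccc(/C=C/c2cc(OC)cc(OC)c2/C=C/C(=O)c2ccc(N)cc2)cc1` gives 2.8 ug/mL
Compound 2 `COc1ccc(/C=C/c2cc(OC)cc(OC)c2/C=C/C(=O)c2ccc(Cl)cc2)cc1` gives 4.9 ug/mL
Compound 3 `COc1ccc(/C=C/c2cc(OC)cc(OC)c2/C=C/C(=O)c2ccccc2C)cc1` gives 6.1 ug/mL

All three values come from a functional assay on B16-F10 cells (Mus musculus) for antiproliferative activity, read by MTT assay, with a stated time of 48 h (a lower number here means a stronger inhibitor, a higher number a weaker inhibitor), and share one core. Compound 3 stands level with compound 2 within the scatter, and apart from compound 1 only modestly. The next compound is compound 4 `COc1ccc(/C=C/c2cc(OC)cc(OC)c2/C=C/C(=O)c2ccc(-c3ccccc3)cc2)cc1`, in which 4-phenylphenyl takes the place of 2-methylphenyl on a carbonyl carbon: 4-phenylphenyl in place of 2-methylphenyl on a carbonyl carbon. Two measured steps also exchange the group at this place and so bear on the change: a 2.2-fold higher number from compound 1 to compound 3 (0.34 log units; beyond the scatter) and a 1.2-fold higher number from compound 2 to compound 3 (0.10 log units; within the scatter). Within the data shown here, both are small, but no measured compound carries 4-phenylphenyl, so the data offer no direct precedent. In this assay no step beyond the scatter is therefore expected, and the estimated change is a 1.2-fold lower number from compound 3 to compound 4 (0.07 log units; within the scatter). The estimate for compound 4 is 5.2 ug/mL, with an expected range from 2.6 ug/mL to 10.5 ug/mL.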

Compound 4, half-maximal inhibitory concentration: 10.6 ug/mL
Compound 4: middle estimate off by 2.0-fold (0.31 log units), on the low side; measured number above the stated range.
By their numbers in this assay, from the lowest: compounds 1, 2, 3 and 4 (each within the scatter of the next, the first and the last beyond it).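

In this assay, a second aromatic ring on the carbonyl carbon, with 4-phenylphenyl replacing 2-methylphenyl, gives a 1.7-fold higher number from compound 3 to compound 4 (0.24 log units; within the scatter) and so leaves compound 4 level with compound 3. Measured against the other two compounds, the change is clearer: phenyl in place of chloro gives a 2.2-fold higher number from compound 2 to compound 4 (0.34 log units; beyond the scatter) and phenyl in place of amino gives a 3.8-fold higher number from compound 1 to compound 4 (0.58 log units; beyond the scatter), so this place accepts the larger group at only a modest cost relative to compound 1 and compound 2. Nothing measured here speaks to why these steps have the size they do.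

The compounds shown leave open how an unsubstituted phenyl or a 4-dimethylaminophenyl on the carbonyl carbon would read in this assay. They also leave open whether a 4-carboxyphenyl or a 4-hydroxyphenyl there would stand nearer to compound 1 or to compound 4.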